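Swapping the aryl group on an oxazole-based amidase inhibitor

This account rests on a few compounds, and the source may have more. Where it says the series, first, only, none or still open, it means among the compounds named here.

Compound 1 `Nc1cccc(-c2cnc(C(=O)CCCCCCc3ccccc3)o2)c1` is the reference point here. In an assay (Rattus norvegicus) for inhibition of Fatty-acid amide hydrolase 1 (Homo sapiens) (a lower number here means a stronger inhibitor, a higher number a weaker inhibitor), compound 1 gives 19 nM, the lowest number among the three measured compounds. Compound 2 `O=C(O)c1ccc(-c2cnc(C(=O)CCCCCCc3ccccc3)o2)cc1` gives 60 nM and compound 3 `N#Cc1ccc(-c2cnc(C(=O)CCCCCCc3ccccc3)o2)cc1` gives 40 nM. Both are weaker: a 3.2-fold higher number from compound 1 to compound 2 (0.50 log units; beyond the scatter) and a 2.1-fold higher number from compound 1 to compound 3 (0.32 log units; beyond the scatter), while the two of them sit close together, with a 1.5-fold lower number from compound 2 to compound 3 (0.18 log units; within the scatter).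

Compound 4 `NC(=O)c1cccc(-c2cnc(C(=O)CCCCCCc3ccccc3)o2)n1` is not yet measured. It differs from compound 1 as follows: 6-carbamoylpyridin-2-yl in place of 3-aminophenyl on an aromatic carbon. Among the measured compounds shown here, no measured step covers exactly this change; the nearest guidance comes from compound 2 and compound 3, where every replacement of the 3-aminophenyl has so far raised the number by a modest amount. That pattern rests on only two cases, so the expectation is tentative.

Compound 4 is therefore expected to be somewhat weaker than compound 1, with an estimated step of a 2.4-fold higher number from compound 1 to compound 4 (0.37 log units; beyond the scatter). The estimated value for compound 4 in this assay is 45 nM, with a likely range from 15 nM to 150 nM.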

Compound 4, inhibition constant: 1 nM
Beside the measured number, compound 4's estimate is 45-fold (1.65 log units) above it, and the stated range ends above it.
By their numbers in this assay, from the lowest: compound 4; then compound 1; then compounds 3 and 2 (each within the scatter of the next).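

Among the compounds shown here, until this result, both replacements of the 3-aminophenyl at this place on the shared core had raised the number in this assay, but the 6-carbamoylpyridin-2-yl group reverses that direction, with a 19-fold lower number from compound 1 to compound 4 (1.28 log units; beyond the scatter). The gap is wider against the other two aryl groups, with a 40-fold lower number from compound 3 to compound 4 (1.60 log units; beyond the scatter) and a 60-fold lower number from compound 2 to compound 4 (1.78 log units; beyond the scatter), so among these compounds, changes at this one place range from modest losses to a large gain. No available measurement explains this gain.

The new group brings a ring nitrogen and a carbamoyl group together, so the compounds shown cannot separate what each contributes. An unsubstituted pyridin-2-yl group and a phenyl ring bearing a carbamoyl group would be the direct tests of the two parts.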